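A few compounds are considered here, and "the series" means these few. Any claim that something is new, unique, unknown or untested is made for them only; others in the source may bear on it.

Working notes on the series.

Compound 1 `Cc1cc(C(=O)N2CCCCc3ccccc32)ccc1CNC(=O)Nc1c(F)cccc1F` is tested in a functional assay on HEK293 cells for agonist activity at Vasopressin V2 receptor (Homo sapiens), read by a luciferase reporter and cAMP accumulation (a lower number here means that less compound is needed, a higher number that more compound is needed for the effect), where compound 1 gives 2.1 nM. Among the measured compounds shown here, compound 2 `CCc1cc(C(=O)N2CCCCc3ccccc32)ccc1CNC(=O)Nc1c(F)cccc1F` is the only other measured member; in this assay compound 2 gives 10 nM. For the measured compounds named here, the one measured step between them, a 4.8-fold higher number from compound 1 to compound 2 (0.68 log units; beyond the scatter), sets compound 1 at the lowest of the two numbers so far, with compound 2 as its nearest neighbour at a clearly higher value.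

Compound 3 `Cc1cc(C(=O)N2CCCCc3ccccc32)ccc1CNC(=O)Nc1ccccc1F` differs from compound 1 by hydrogen in place of fluoro on an aromatic carbon, that is, the 2,6-difluorophenyl of the urea becomes a 2-fluorophenyl. Going by the values given here, none of the measured steps touches this part of the molecule: the only one recorded concerns the saturated chain carbon on the core, not the fluoro-bearing ring. Among the compounds with values here, there is therefore no direct precedent for the size of this step in this assay. Taking the loss of one fluoro on the urea ring as a change likely to cost little, the expected step from compound 1 to compound 3 is a 1.9-fold higher number from compound 1 to compound 3 (0.28 log units; within the scatter), a modest rise at most. Compound 3 is accordingly estimated at 4 nM, with a range from 1.5 nM to 12 nM.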

Compound 3, half-maximal effective concentration: 30 nM
Estimate against measurement, compound 3: 7.5-fold (0.88 log units) below; measured number outside the range, above it.
By their numbers in this assay, from the lowest: compound 1; then compound 2; then compound 3.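

In this assay the change from 2,6-difluorophenyl to 2-fluorophenyl gives a 14-fold higher number from compound 1 to compound 3 (1.15 log units; beyond the scatter), so the urea ring, until now untouched by any measured step, is a place where a single fluoro counts. This one heavy atom on an aromatic carbon, with no hydrogen-bond donor or acceptor and no net charge entering or leaving, moves the number by a large step, whereas the change on the saturated chain carbon of the core gives the modest 4.8-fold higher number from compound 1 to compound 2 (0.68 log units; beyond the scatter). Nothing measured here bears on why the second fluoro matters so much at this place.

The compounds shown leave open whether chloro, methyl or methoxy on this aromatic carbon would hold the number near that of compound 1, or whether only fluoro does so. They also leave open how far the number moves with the plain phenyl urea, which carries no fluoro at all, and whether the ethyl on the core and the loss of fluoro on the urea ring would add up in one molecule.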